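A few compounds are considered here, and "the series" means these few. Any claim that something is new, unique, unknown or untested is made for them only; others in the source may bear on it.

The measured compounds:
Compound 1 `CCOC(=O)[C@@H](NC(=O)/C=C/c1ccc(O)c(O)c1)C(C)C` gives 19600 nM in a functional assay, read by spectrophotometry, with a stated time of 30 min; a lower number here means a stronger inhibitor, a higher number a weaker inhibitor.
Compound 2 `CCOC(=O)[C@@H](NC(=O)/C=C/c1ccc(OC(C)=O)c(OC)c1)C(C)C` gives only a limit, > 500000 nM, in this assay.
Compound 3 `CCOC(=O)[C@H](CC(C)C)NC(=O)/C=C/c1ccc(OC(C)=O)c(OC)c1` likewise gives only a limit, > 500000 nM, in this assay.

Within the data shown here, compound 1 therefore stands alone as the single number in this assay; the other two values are limits, both at the limit of > 500000 nM in this assay, at which 2 of the 3 values shown sit. The unmeasured compound 4 `CCOC(=O)[C@H](CC(C)C)NC(=O)/C=C/c1ccc(O)c(O)c1` is to be tested in this assay. It differs from compound 1 in one place: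
isobutyl in place of isopropyl on a saturated chain carbon bound to an amide-type nitrogen and a carbonyl carbon

Among the measured compounds shown here, only one measured step bears on this change. The same replacement, on the same saturated chain carbon, separates compound 2 from compound 3, and that step is a step that the two limits leave unreadable from compound 2 to compound 3. For the measured compounds named here, since both ends of it are limits, it gives no reading of size or direction, and no other pair in the set repeats the exchange. The account thus has no measured basis for expecting a step beyond the scatter in this assay from compound 1 to compound 4.

On that basis compound 4 is expected to give about 19600 nM in this assay, with a range from 6000 nM to 65000 nM. The step this estimate means, from compound 1 to compound 4, is no change at the digits printed from compound 1 to compound 4 (within the scatter), expected to lie within the usual scatter.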

Compound 4, half-maximal inhibitory concentration: 28600 nM
Compound 4: the middle estimate sits 1.5-fold (0.16 log units) below what was measured; measured number inside the range.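

On the saturated chain carbon bound to an amide-type nitrogen and a carbonyl carbon, the exchange of isopropyl for isobutyl now has a readable size: in this assay it gives a 1.5-fold higher number from compound 1 to compound 4 (0.16 log units; within the scatter). On the core of compound 1, the two chains therefore cannot be told apart in this assay, and this place accepts isobutyl as well as isopropyl. Compound 2 and compound 3 could not show this, and their step cannot be read, because each of them gives only a limit: the limit of > 500000 nM in this assay, at which 2 of the 4 values shown sit.

The compounds shown cover only these two branched chains on this carbon, leaving open how this assay would read a methyl group, a benzyl group, a longer chain, an amine or a carboxylic acid in the same place. The core of compound 1 is also the only one that gives a readable step for this exchange, and whether the same holds on any other core remains an open question.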